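Swapping Ethyl for Pyridin-2-yl on the Piperazine Nitrogen

This account rests on a few compounds, and the source may have more. Where it says the series, first, only, none or still open, it means among the compounds named here.

Compound 1 `COc1ccc(-c2coc3cc(OCCCBr)ccc3c2=O)cc1`: 39700 nM
Compound 2 `COc1ccc(-c2coc3cc(OCCCCSC(=S)N4CCN(C(=O)OC(C)(C)C)CC4)ccc3c2=O)cc1`: 8840 nM
Compound 3 `CCN1CCN(C(=S)SCCCOc2ccc3c(=O)c(-c4ccc(OC)cc4)coc3c2)CC1`: 36900 nM

In a functional assay on ECa-109 cells for inhibition, with ECa-109 cell line (Homo sapiens) as the target, read by MTT assay, with a stated time of 48 h (on this read-out higher numbers stand for weaker inhibition and lower numbers for stronger inhibition), compound 3 gives the second highest of the three numbers, sitting within the scatter of compound 1 while compound 2 gives a lower number, a gap beyond the scatter. Going by the values given here, the only single-site step seen, a 1.1-fold lower number from compound 1 to compound 3 (0.03 log units; within the scatter), changes the chain end, not the piperazine substituent, so no measured step bears directly on the change to compound 4 `COc1ccc(-c2coc3cc(OCCCSC(=S)N4CCN(c5ccccn5)CC4)ccc3c2=O)cc1`, which is pyridin-2-yl in place of ethyl on an amine nitrogen in a ring. Compound 2 carries a different group on that nitrogen and a longer chain, and its lower number hints that the piperazine substituent can matter. A modest step of a 1.8-fold lower number from compound 3 to compound 4 (0.27 log units; within the scatter) toward stronger inhibition is therefore expected, giving an estimated 20000 nM for compound 4, within 7000 nM to 60000 nM.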

Compound 4, half-maximal inhibitory concentration: 38300 nM
The estimate for compound 4 lay 1.9-fold (0.28 log units) below the measured number; the range from low to high includes it.
By their numbers in this assay, from the lowest: compound 2; then compounds 3, 4 and 1 (each within the scatter of the next).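

In this assay, pyridin-2-yl in place of ethyl on this amine nitrogen in a ring gives a 1.0-fold higher number from compound 3 to compound 4 (0.02 log units; within the scatter), so this first direct reading at the position cannot tell the two groups apart. An aromatic ring on this nitrogen thus gives a number no different, within the scatter, from that of the small ethyl group. Nothing measured here offers an explanation for this result.

From the compounds shown here alone, compound 2 differs from compound 4 in both chain and nitrogen group, so which of the two matters remains open. Also open, going by these compounds, is how a benzyl group or a carboxylic acid on this nitrogen would read.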